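This account rests on a few compounds, and the source may have more. Where it says the series, first, only, none or still open, it means among the compounds named here.

In a functional assay on U-373MG ATCC cells (Homo sapiens) for inhibition, read by colorimetric assay and MTT assay, with a stated time of 72 h (a lower number here means a stronger inhibitor, a higher number a weaker inhibitor), compound 1 `C=CCCCCOc1ccccc1-c1cnc(OCCCCC=C)n1C` gives 7000 nM. Compound 2 `C=CCCCCOc1ncc(-c2ccccc2OC)n1C` gives 9000 nM. That is a 1.3-fold higher number from compound 1 to compound 2 (0.11 log units; within the scatter), so these two numbers stand level. Compound 3 `C=CCCOc1ccccc1-c1cnc(S(=O)(=O)c2ccccc2)n1C` reads > 100000 nM, which is a limit and not a number.

Compound 4 `C=CCCCCOc1ccccc1-c1cnc(NC(=O)CCCC=C)n1C` keeps the core of compound 1 but puts ((pent-4-en-1-yl)carbonyl)amino in place of (hex-5-en-1-yl)oxy on an aromatic carbon. Among the measured compounds shown here, the only measured step, a 1.3-fold higher number from compound 1 to compound 2 (0.11 log units; within the scatter), changes a different place, so it offers only a loose guide to this swap. Resting on that small step, the expected change is a 1.4-fold higher number from compound 1 to compound 4 (0.15 log units; within the scatter), with nothing beyond the scatter anticipated. For compound 4 the estimate is 10000 nM, with an expected range from 3000 nM to 40000 nM.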

Compound 4, half-maximal inhibitory concentration: 7000 nM
Compound 4: the middle estimate sits 1.4-fold (0.15 log units) above what was measured; low and high end bracket the measured number.
By their numbers in this assay, from the lowest: compounds 1, 4 and 2 (each within the scatter of the next). At a limit, above all of these: compound 3.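

At this aromatic carbon, between two ring nitrogen atoms, ((pent-4-en-1-yl)carbonyl)amino in place of (hex-5-en-1-yl)oxy gives no change at the digits printed from compound 1 to compound 4 (within the scatter) in this assay. So this position, which no earlier step touched, accepts a different link to its chain, with a hydrogen-bond donor added, and the reading holds. Nothing measured here accounts for the two groups reading alike. From the compounds shown here alone, what a plain amine or a carboxylic acid on this carbon would read stays open, as does whether a longer chain on the carbonyl would hold the reading.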